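From carbamoyl to dimethylcarbamoyl at a solubility limit

The source may hold more compounds than are shown below. What is called first, only, known or untested is meant among the compounds shown, and "the series" means these compounds.

- Compound 1 `COc1nc(C2=NN(c3ccc(C#N)c(C)c3)[C@@H](C3CCCC3)C2)ccc1C(=O)N(C)C`: < 25000 nM
- Compound 2 `COc1nc(C2=NN(c3ccc(C#N)c(C)n3)[C@@H](C3CCCC3)C2)ccc1C(N)=O`: < 25000 nM

In a physicochemical assay for solubility, in phosphate buffer, measured as kinetic solubility, at pH 6.5 (on this read-out higher numbers stand for higher solubility and lower numbers for lower solubility), compound 2 reads < 25000 nM, which is a limit of the assay and not a number. Compound 1 reads < 25000 nM, which is also a limit. Compound 3 `COc1nc(C2=NN(c3ccc(C#N)c(C)n3)[C@@H](C3CCCC3)C2)ccc1C(=O)N(C)C` has not been measured. It differs from compound 2 in one place, with dimethylamino in place of amino on a carbonyl carbon. Among the compounds with values here, no measured step is available as a guide. The estimated change is a step that the limit leaves unreadable from compound 2 to compound 3, and no shift beyond the usual scatter is expected in this assay, in either direction. Compound 3 is expected at 18000 nM, with an estimated range of 6000 nM to 40000 nM.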

Compound 3, solubility: < 25000 nM
Compound 3: a limit, no number (the forecaster's own chance of this, stated with the estimate: 70%); the middle value does not contradict the limit.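

Compound 3 also gives a limit and not a number, so its steps from compound 1 and compound 2 cannot be read: the limit of < 25000 nM in this assay, at which 3 of the 3 values shown sit.

The compounds shown leave open how far apart these three compounds truly lie in this assay, and whether either single change moves the result at all.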